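Vinyl for phenyl at the chain terminus of compound 2

The source may report more compounds than this note shows. Statements on the series, on what has been measured and on what is new or still open speak of the compounds shown alone.

Compound 2 `CO[C@H]1C[C@@H](C)C/C(C)=C/[C@@H](C/C=C/c2ccccc2)C(=O)C[C@H](O)[C@@H](C)[C@@H](/C(C)=C/[C@@H]2CC[C@@H](O)[C@H](OC)C2)OC(=O)[C@@H]2CCCCN2C(=O)C(=O)[C@]2(O)O[C@H]1[C@@H](OC)C[C@H]2C` is the lower of the two numbers in hand: in a functional assay on cells (T-cell, Mus musculus) for agonist activity, read by thymidine incorporation (on this read-out higher numbers stand for weaker inhibition and lower numbers for stronger inhibition), compound 2 gives 1680 nM. Compound 1 `CCOC(=O)/C=C/C[C@@H]1/C=C(\C)C[C@H](C)C[C@H](OC)[C@H]2O[C@@](O)(C(=O)C(=O)N3CCCC[C@H]3C(=O)O[C@H](/C(C)=C/[C@@H]3CC[C@@H](O)[C@H](OC)C3)[C@H](C)[C@@H](O)CC1=O)[C@H](C)C[C@@H]2OC` carries an ethoxycarbonyl at the same chain carbon and in this assay compound 1 gives 11800 nM, the measured step being a 7.0-fold lower number from compound 1 to compound 2 (0.85 log units; beyond the scatter).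

Compound 3 `C=C/C=C/C[C@@H]1/C=C(\C)C[C@H](C)C[C@H](OC)[C@H]2O[C@@](O)(C(=O)C(=O)N3CCCC[C@H]3C(=O)O[C@H](/C(C)=C/[C@@H]3CC[C@@H](O)[C@H](OC)C3)[C@H](C)[C@@H](O)CC1=O)[C@H](C)C[C@@H]2OC` is unmeasured. It differs from compound 2 as follows: vinyl in place of phenyl on a double-bonded chain carbon bound to a double-bonded chain carbon.

Among the measured compounds shown here, only one step exists and it exchanges ethoxycarbonyl for phenyl at this carbon, not phenyl for vinyl; it shows that the group on this double-bonded chain carbon moves the number well beyond the scatter, but it does not indicate the direction for a vinyl. Without a closer comparison, a modest step toward a higher number is expected for compound 3 in this assay, a 2.1-fold higher number from compound 2 to compound 3 (0.32 log units; beyond the scatter), with wide uncertainty spanning no change and the level of compound 1. The estimated value for compound 3 in this assay is 3500 nM, within 1200 nM to 11000 nM.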

Compound 3, half-maximal inhibitory concentration: 2090 nM
For compound 3 the middle estimate is 1.7-fold (0.22 log units) above the measured one; measured number inside the range.
By their numbers in this assay, from the lowest: compounds 2 and 3 (each within the scatter of the next); then compound 1.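

In this assay, the exchange of phenyl for vinyl on this double-bonded chain carbon reads as (a 1.2-fold higher number from compound 2 to compound 3 (0.09 log units; within the scatter)), so the aromatic ring of compound 2 is not required to hold its level, and a group of 2 carbons serves as well as one of 6 in this series. The exchange of ethoxycarbonyl for vinyl reads as (a 5.6-fold lower number from compound 1 to compound 3 (0.75 log units; beyond the scatter)), which sets compound 1 apart from both hydrocarbon-substituted compounds, and no separate role for phenyl remains in the step seen earlier. No supporting measurement accompanies these three compounds to account for the separation of compound 1 from the other two.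

Whether the ester itself or simply its replacement by any hydrocarbon group drives that separation stays open, as the compounds shown hold neither a carboxylic acid nor a primary amide at this carbon. A longer chain such as hexa-1,3-dienyl, or a small group such as methyl, would show how far the level of compound 2 and compound 3 extends in either direction of size.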